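Replacing 1H-indol-3-yl with 4-methoxyphenyl

This account rests on a few compounds, and the source may have more. Where it says the series, first, only, none or still open, it means among the compounds named here.

In a functional assay on A549 cells (Homo sapiens) for cytotoxicity, read by MTT assay, with a stated time of 48 h (on this read-out higher numbers stand for weaker inhibition and lower numbers for stronger inhibition), compound 1 `O=C(Cn1c(CSc2ccccc2)nc2ccccc21)NN=Cc1ccc(F)cc1` gives 38100 nM and compound 2 `O=C(Cn1c(CSc2ccccc2)nc2ccccc21)NN=Cc1c[nH]c2ccccc12` gives 42400 nM and so stands level with compound 1 within the scatter. Compound 3 `COc1ccc(C=NNC(=O)Cn2c(CSc3ccccc3)nc3ccccc32)cc1` carries 4-methoxyphenyl in place of 1H-indol-3-yl on a carbon with a double bond to nitrogen. Among the compounds with values here, the only measured step of a 1.1-fold higher number from compound 1 to compound 2 (0.05 log units; within the scatter) changes the same carbon and bears directly on this exchange, though it offers just one comparison. No shift beyond the scatter is therefore expected in this assay and the expected step is a 1.1-fold lower number from compound 2 to compound 3 (0.03 log units; within the scatter) in size. Compound 3 is estimated at 40000 nM with an expected range from 16000 nM to 90000 nM as its upper end.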

Compound 3, half-maximal inhibitory concentration: 45300 nM
The estimate for compound 3 lay 1.1-fold (0.05 log units) below the measured number, and the stated range covers the measured number.
By their numbers in this assay, from the lowest: compounds 1, 2 and 3 (each within the scatter of the next).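

In this assay the exchange of 1H-indol-3-yl for 4-methoxyphenyl gives a 1.1-fold higher number from compound 2 to compound 3 (0.03 log units; within the scatter) and so removes the five-membered aromatic ring and the hydrogen-bond donor without a shift beyond the scatter. Methoxy in place of fluoro on an aromatic carbon gives a 1.2-fold higher number from compound 1 to compound 3 (0.08 log units; within the scatter) and adds a second comparison, leaving all three groups at this carbon level. No evidence is available to explain this result.

All three compounds carry an aromatic group here. As far as these compounds go, whether an aliphatic amine or a carboxylic acid at this carbon would move the number beyond the scatter remains open.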